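Para substituents on the sulfonamide aryl ring: ethyl to fluoro

The source may hold more compounds than are shown below. What is called first, only, known or untested is meant among the compounds shown, and "the series" means these compounds.

Compound 1 `Cc1ccc(NS(=O)(=O)c2cccc(CCCCCCNC(=O)/C=C/c3cccnc3)c2)cc1` gives 6.92 nM
Compound 2 `Cc1ccc(C)c(NS(=O)(=O)c2cccc(CCCCCCNC(=O)/C=C/c3cccnc3)c2)c1` gives 2.58 nM
Compound 3 `CCc1ccc(NS(=O)(=O)c2cccc(CCCCCCNC(=O)/C=C/c3cccnc3)c2)cc1` gives 34.6 nM

In a functional assay on Huh-7 cells (Homo sapiens) for inhibition, read by CCK-8 assay, with a stated time of 72 h (on this read-out lower numbers stand for stronger inhibition and higher numbers for weaker inhibition), compound 3 has the highest number of the three (34.6 nM) and is the weakest so far. Compound 4 `O=C(/C=C/c1cccnc1)NCCCCCCc1cccc(S(=O)(=O)Nc2ccc(F)cc2)c1` carries fluoro in place of ethyl on an aromatic carbon and is otherwise unchanged. Among the measured compounds shown here, no fluoro compound has been measured yet. The nearest evidence is a 5.0-fold higher number from compound 1 to compound 3 (0.70 log units; beyond the scatter), where a modest step accompanies the 4-ethylphenyl group. The large 13-fold higher number from compound 2 to compound 3 (1.13 log units; beyond the scatter) also points the same way, while a 2.7-fold lower number from compound 1 to compound 2 (0.43 log units; beyond the scatter) is a modest step that does not involve ethyl. The estimated change is a 3.5-fold lower number from compound 3 to compound 4 (0.54 log units; beyond the scatter) and so a modest step to a lower number. For compound 4 the expected value is 10 nM within an estimated range of 3 nM to 35 nM overall.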

Compound 4, half-maximal inhibitory concentration: 4.28 nM
Estimate against measurement, compound 4: 2.3-fold (0.37 log units) above, within the range that was stated.
By their numbers in this assay, from the lowest: compounds 2, 4 and 1 (each within the scatter of the next, the first and the last beyond it); then compound 3.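

In this assay the weakening seen with 4-ethylphenyl does not carry over to 4-fluorophenyl: an 8.1-fold lower number from compound 3 to compound 4 (0.91 log units; beyond the scatter). Fluoro and methyl on this carbon cannot be told apart, with a 1.6-fold lower number from compound 1 to compound 4 (0.21 log units; within the scatter), and 4-fluorophenyl also matches 2,5-dimethylphenyl, with a 1.7-fold higher number from compound 2 to compound 4 (0.22 log units; within the scatter). Of the three groups compared on this carbon, only ethyl stands apart.

Nothing in hand explains why ethyl differs. Open remain whether a longer chain such as propyl follows ethyl, and where chloro or methoxy on this carbon would fall.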